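Trimming an aryl substituent: from compound 1 to compound 3

The source may report more compounds than this note shows. Statements on the series, on what has been measured and on what is new or still open speak of the compounds shown alone.

Measured so far:
compound 1, `CCN(Cc1cccs1)C(=O)COc1ccc(C(C)C)cc1`: 397 nM
compound 2, `C=CCN(Cc1cccs1)C(=O)COc1ccc(C)cc1`: 20 nM

Of the compounds shown here, two have been measured in an assay on HEK293 cells for agonist activity at transient receptor potential cation channel subfamily M member 8 (Homo sapiens), read by fluorescence and calcium flux, with a stated time of 15 min; a higher number here means that more compound is needed for the effect, a lower number that less compound is needed. Compound 1 stands at the higher of the two numbers, with 397 nM in this assay. Compound 2 gives 20 nM, a much lower number, well beyond the scatter; the two compounds differ in more than one place, so this gap cannot be assigned to a single change.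

Compound 3, `CCc1ccc(OCC(=O)N(CC)Cc2cccs2)cc1`, differs from compound 1 in one place: hydrogen in place of methyl on a saturated chain carbon bound to an aromatic carbon and a saturated chain carbon. Going by the values given here, since the only other measured compound, compound 2, carries a methyl on the aromatic ring and gives 20 nM, a move in the same direction seems plausible, though the second difference in compound 2 leaves this uncertain. In this assay a moderate drop, a 2.6-fold lower number from compound 1 to compound 3 (0.42 log units; beyond the scatter), is expected. Compound 3 is estimated at 150 nM, within 50 nM to 500 nM.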

Compound 3, half-maximal effective concentration: 67 nM
Beside the measured number, compound 3's estimate is 2.2-fold (0.35 log units) above it, within the range that was stated.
By their numbers in this assay, from the lowest: compound 2; then compound 3; then compound 1.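

In this assay, going by these compounds alone, trimming isopropyl to ethyl gives a 5.9-fold lower number from compound 1 to compound 3 (0.77 log units; beyond the scatter) and provides the one comparison here that isolates a single change. Hydrogen in place of methyl on a saturated chain carbon bound to an aromatic carbon and a saturated chain carbon removes just one carbon, yet less compound is needed for the effect, so the full isopropyl group is not required for this activity. Nothing given here bears on why this single carbon matters.

Going by these compounds, whether the number would keep falling with a smaller group in place of ethyl remains open, since compound 2 carries a methyl on the aromatic ring but also differs from compound 3 elsewhere. On these data alone, how a longer chain such as butyl or a group of another kind such as an amine would behave in its place also remains unknown.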